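This account rests on a few compounds, and the source may have more. Where it says the series, first, only, none or still open, it means among the compounds named here.

Compound 1 `CCCn1c(=O)[nH]c2nc(-c3ccc(S(=O)(=O)N4CCN(c5ccccc5Br)CC4)cc3)[nH]c2c1=O` gives in an assay on CHO cells for displacement of a labelled ligand from adenosine receptor A3 (Homo sapiens), read by scintillation counting, with a stated time of 45 min, in the presence of a further agent that is not named here (a lower number here means a stronger inhibitor, a higher number a weaker inhibitor), only the assay's limit > 1000 nM. Compound 2 `CCCn1c(=O)[nH]c2nc(-c3ccc(S(=O)(=O)N4CCN(c5ccc(C)cc5)CC4)cc3)[nH]c2c1=O` gives in this assay the limit > 1000 nM. Compound 3 `CCCn1c(=O)[nH]c2nc(-c3ccc(S(=O)(=O)N4CCN(C(C)c5ccccc5)CC4)cc3)[nH]c2c1=O` gives in this assay the limit > 1000 nM.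

Compound 3 thus stands where every measured compound stands, at the limit described by the limit of > 1000 nM in this assay, at which 3 of the 3 values shown sit. The change to compound 4 `CCCn1c(=O)[nH]c2nc(-c3ccc(S(=O)(=O)N4CCN(Cc5ccc(Br)c(F)c5)CC4)cc3)[nH]c2c1=O` is 4-bromo-3-fluorobenzyl in place of 1-phenylethyl on an amine nitrogen in a ring. The steps that touch the same amine nitrogen, a step that the two limits leave unreadable from compound 1 to compound 3 and a step that the two limits leave unreadable from compound 2 to compound 3, as well as a step that the two limits leave unreadable from compound 1 to compound 2, are all unreadable, since both ends sit at the limit. No direction can be read from them; the expected step that the limit leaves unreadable from compound 3 to compound 4 therefore reflects the limit rather than a trend. Compound 4 is estimated at 3000 nM, with a range from 1000 nM to 30000 nM.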

Compound 4, inhibition constant: > 1000 nM
Compound 4: a limit, no number; the forecaster's own chance of this, stated with the estimate: 85%; the middle value is on the limit's open side.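

Within the data shown here, compound 4 also gives only the limit > 1000 nM in this assay, so no step from compound 1, compound 2 or compound 3 to compound 4 can be read: the limit of > 1000 nM in this assay, at which 4 of the 4 values shown sit. The compounds shown leave open whether any group on this amine nitrogen changes the inhibition constant, as none of them gives a number.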